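The source may hold more compounds than are shown below. What is called first, only, known or untested is meant among the compounds shown, and "the series" means these compounds.

Measured so far in a functional assay on KB cells (Homo sapiens) for cytotoxicity, read by sulforhodamine B assay; on this read-out lower numbers stand for stronger inhibition and higher numbers for weaker inhibition:
compound 1 `C=C1[C@@H](OC(C)=O)C[C@@H]2[C@](C)(COC=O)[C@H](OC(C)=O)CC[C@@]2(C)[C@@H]1C[C@@H](Nc1ccc(Br)cc1)C1=CCOC1=O`, 24000 nM
compound 2 `C=C1CC[C@@H]2[C@](C)(CO[Si](C)(C)C(C)(C)C)[C@H](OC(C)=O)CC[C@@]2(C)[C@@H]1C/C=C1/C(=O)OC[C@H]1OC(C)=O`, 5050 nM
compound 3 `C=C1[C@@H](OC(C)=O)C[C@@H]2[C@](C)(CO[Si](C)(C)C(C)(C)C)[C@H](OC(C)=O)CC[C@@]2(C)[C@@H]1C/C=C1/C(=O)OC[C@H]1OC(C)=O`, 5020 nM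

Compound 1 stands at the highest of the three numbers; compound 2 and compound 3 both sit clearly lower, beyond the scatter. Within the data shown here, the one single-point step measured so far, a 1.0-fold lower number from compound 2 to compound 3 (0.00 log units; within the scatter), concerns an acetoxy entering on a saturated ring carbon of the shared core and changes nothing beyond the scatter.

Compound 4 `C=C1[C@@H](OC(C)=O)C[C@@H]2[C@](C)(COC=O)[C@H](OC(C)=O)CC[C@@]2(C)[C@@H]1C[C@@H](Nc1ccc(F)cc1)C1=CCOC1=O` is derived from compound 1 by fluoro in place of bromo on an aromatic carbon. Among the measured compounds shown here, no measured step touches the halogen on this aryl ring, so the step of a 1.0-fold lower number from compound 2 to compound 3 (0.00 log units; within the scatter) does not bear on it, and nothing else does. For the measured compounds named here, with no relevant precedent, the expectation for this assay is a step of no size beyond the scatter, with the direction open, no change at the digits printed from compound 1 to compound 4 (within the scatter).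

Compound 4 is therefore estimated at 24000 nM, within a range of 9000 nM to 60000 nM.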

Compound 4, half-maximal inhibitory concentration: 22900 nM
Compound 4: middle estimate off by 1.0-fold (0.02 log units), on the high side, and the stated range covers the measured number.
By their numbers in this assay, from the lowest: compounds 3 and 2 (each within the scatter of the next); then compounds 4 and 1 (each within the scatter of the next).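

In this assay, among these compounds, the swap of fluoro for bromo on the aromatic carbon, para to a large group, reads as a 1.0-fold lower number from compound 1 to compound 4 (0.02 log units; within the scatter) and is the first measured step at this ring. Between these two halogens, the position shows no change beyond the scatter. No available evidence explains this result.

On these data alone, whether a methoxy group, an amine or a carboxylic acid at this carbon would shift the number remains open. So does the effect of replacing the whole (4-bromophenyl)amino group.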